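Fluoro for Bromo in a Flat Series

The source may report more compounds than this note shows. Statements on the series, on what has been measured and on what is new or still open speak of the compounds shown alone.

In a functional assay on SK-OV-3 cells (Homo sapiens) for cytotoxicity, read by sulforhodamine B assay, with a stated time of 48 h (on this read-out lower numbers stand for stronger inhibition and higher numbers for weaker inhibition), compound 1 `Cc1ccc2nc(NCCCCOc3cc(O)c4c(=O)cc(-c5ccccc5)oc4c3)sc2c1` gives 48.4 ug/mL, compound 2 `O=c1cc(-c2ccccc2)oc2cc(OCCCCNc3nc4ccc(Cl)cc4s3)cc(O)c12` gives 39.3 ug/mL and compound 3 `O=c1cc(-c2ccccc2)oc2cc(OCCCCNc3nc4ccc(Br)cc4s3)cc(O)c12` gives 35.1 ug/mL. Compound 3 therefore stands level with the other two, within the scatter of both. Compound 4 `O=c1cc(-c2ccccc2)oc2cc(OCCCCNc3nc4ccc(F)cc4s3)cc(O)c12` differs from compound 3 in a single place: fluoro in place of bromo on an aromatic carbon. Fluoro takes the place of bromo on an aromatic carbon. Among the measured compounds shown here, the closest precedent is the swap of one halogen for another, a 1.1-fold lower number from compound 2 to compound 3 (0.05 log units; within the scatter). The swaps of methyl for a halogen, a 1.2-fold lower number from compound 1 to compound 2 (0.09 log units; within the scatter) and a 1.4-fold lower number from compound 1 to compound 3 (0.14 log units; within the scatter), also stayed within the scatter. No change beyond the scatter is therefore expected, and the estimated move in this assay is a 1.1-fold higher number from compound 3 to compound 4 (0.06 log units; within the scatter). For compound 4 the estimate is 40 ug/mL, with an expected range from 22 ug/mL to 70 ug/mL.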

Compound 4, half-maximal inhibitory concentration: 33.7 ug/mL
Beside the measured number, compound 4's estimate is 1.2-fold (0.07 log units) above it, and the stated range covers the measured number.
By their numbers in this assay, from the lowest: compounds 4, 3, 2 and 1 (each within the scatter of the next).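

Fluoro now joins chloro, bromo and methyl on this aromatic carbon of the benzothiazole group, and in this assay the steps are a 1.0-fold lower number from compound 3 to compound 4 (0.02 log units; within the scatter), a 1.2-fold lower number from compound 2 to compound 4 (0.07 log units; within the scatter) and a 1.4-fold lower number from compound 1 to compound 4 (0.16 log units; within the scatter). All three lie within the usual scatter, so among these four compounds, the choice of group at this position does not separate them on this read-out. On these data alone, whether an amine, a carboxylic acid or a methoxy group on the same carbon would give a number outside that scatter stays open. Nothing available explains why these four compounds read alike.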